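The source may hold more compounds than are shown below. What is called first, only, known or untested is meant among the compounds shown, and "the series" means these compounds.

Compound 3, `O=C(/C=C1\CCc2ccc(F)cc21)NCc1ccccc1`, is the reference point of this step. In a functional assay on the whole organism with Rattus norvegicus as the target (on this read-out lower numbers stand for an effect already at smaller amounts and higher numbers for an effect only at larger amounts of compound), compound 3 gives 8 mg/kg. That is the low end of the three numbers measured, though compound 1, `O=C(/C=C1\CCc2ccc(F)cc21)NC1CCCC1`, with 11 mg/kg in this assay lies within the scatter of compound 3; the step of a 1.4-fold lower number from compound 1 to compound 3 (0.14 log units; within the scatter) is therefore not a real change. Compound 2, `NC(=O)/C=C1\CCc2cc(F)c(F)cc21`, gives 17 mg/kg in this assay, a value beyond the scatter from compound 3, but compound 2 differs from compound 3 in more than one place, so this is not a single step.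

Compound 4, `NC(=O)/C=C1\CCc2ccc(F)cc21`, differs from compound 3 by hydrogen in place of benzyl on an amide-type nitrogen. Among the compounds with values here, no measured step bears directly on this change: the only single-place step among the measured compounds exchanges one substituent on the amide-type nitrogen for another of similar size, and that was within the scatter. The nearest hint is that compound 2, which also carries hydrogen on the amide-type nitrogen, shows a higher number than compound 3 and compound 1. Compound 4 is therefore expected to show a modest rise in this assay, a 1.9-fold higher number from compound 3 to compound 4 (0.27 log units; within the scatter), to an estimated 15 mg/kg within 7 mg/kg to 32 mg/kg.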

Compound 4, dose for half-maximal effect: 20 mg/kg
Beside the measured number, compound 4's estimate is 1.3-fold (0.12 log units) below it; the range from low to high includes it.
By their numbers in this assay, from the lowest: compounds 3, 1, 2 and 4 (each within the scatter of the next, the first and the last beyond it).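

Within the data shown here, replacing benzyl with hydrogen on the amide-type nitrogen is the first single-place change in this set to go beyond the scatter in this assay (a 2.5-fold higher number from compound 3 to compound 4 (0.40 log units; beyond the scatter)). Replacing cyclopentyl with hydrogen at the same place stays within the scatter (a 1.8-fold higher number from compound 1 to compound 4 (0.26 log units; within the scatter)), so only the change from benzyl gives a clear difference, while hydrogen in place of fluoro on an aromatic carbon also stays within it (a 1.2-fold higher number from compound 2 to compound 4 (0.07 log units; within the scatter)). No measured evidence accounts for these steps.

From the compounds shown here alone, it remains open how a methyl group or a longer chain ending in an amine on the amide-type nitrogen would compare with benzyl, cyclopentyl and hydrogen. Going by these compounds, it is also open whether a chloro or methoxy group on that aromatic carbon would read differently from fluoro and hydrogen.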